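Hexylsulfonyl Replaces Dichlorobenzylsulfanyl on a Coumarin Core

The source may hold more compounds than are shown below. What is called first, only, known or untested is meant among the compounds shown, and "the series" means these compounds.

Compound 1 `CCCSc1nnc(COc2cc(C)c3c(C)cc(=O)oc3c2)o1`: > 100000 nM
Compound 2 `Cc1cc(OCc2nnc(SCc3ccc(Cl)cc3Cl)o2)cc2oc(=O)cc(C)c12`: < 5000 nM

In a functional assay on MCF7 cells (Homo sapiens) for antiproliferative activity, read by MTT assay, with a stated time of 24 h (on this read-out higher numbers stand for weaker inhibition and lower numbers for stronger inhibition), compound 1 gives > 100000 nM, which is a limit of the assay and not a number. In this assay compound 2 gives < 5000 nM, likewise a limit rather than a number. Within the data shown here, compound 2 therefore stands only as a limit, with no exact value, and the single measured step leading to it, an at least 20-fold lower number from compound 1 to compound 2 (1.30 log units; beyond the scatter), is large and beyond the scatter; it brought in an aromatic ring bearing two chlorines.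

Compound 3 `CCCCCCS(=O)(=O)c1nnc(COc2cc(C)c3c(C)cc(=O)oc3c2)o1` differs from compound 2 by hexylsulfonyl in place of (2,4-dichlorobenzyl)sulfanyl on an aromatic carbon. This change removes the very ring that the measured step introduced and replaces it with a plain chain carrying a sulfonyl. A higher number is expected for compound 3 because compound 1 without such a ring gives > 100000 nM. Compound 3 is estimated at 40000 nM, within 5000 nM to 150000 nM. The expected step is an at least 8.0-fold higher number from compound 2 to compound 3 (0.90 log units; beyond the scatter).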

Compound 3, half-maximal inhibitory concentration: > 100000 nM
Compound 3: only a limit was reported; the forecaster's own chance of this, stated with the estimate: 60%; middle value at least 2.5-fold (0.39 log units) away from the limit.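

In this assay, the aromatic carbon of the five-membered ring tolerates this change poorly: replacing (2,4-dichlorobenzyl)sulfanyl with hexylsulfonyl gives an at least 20-fold higher number from compound 2 to compound 3 (1.30 log units; beyond the scatter). Among these compounds, until now, the only group without the aromatic ring was the short propylsulfanyl, and this result shows that a hexyl chain carrying a sulfonyl does not restore the activity of compound 2 either. The step between compound 1 and compound 3 cannot be read, and neither compound gives an exact value: the limit of > 100000 nM in this assay, at which 2 of the 3 values shown sit.

The change removes the dichlorinated ring and brings in the sulfonyl at the same time, so the compounds shown cannot tell which of the two matters. A (2,4-dichlorobenzyl)sulfonyl or a hexylsulfanyl group at this position would separate the two.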